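The source may hold more compounds than are shown below. What is called first, only, known or untested is meant among the compounds shown, and "the series" means these compounds.

The measured compounds in an assay on CHO cells for displacement of a labelled ligand from adenosine receptor A3 (Homo sapiens), read by scintillation counting, tested at 10 uM; on this read-out higher numbers stand for more inhibition at the one concentration tested (going by the name of the read-out) and lower numbers for less inhibition:

compound 1, `Cc1c(-c2ccccc2)sc(N)c1C(=O)c1ccc(Cl)cc1`, gives 1%
compound 2, `Nc1sc(-c2ccccc2)c(-c2ccccc2)c1C(=O)c1ccc(Cl)cc1`, gives 1%
compound 3, `CC(C)(C)Cc1c(-c2cccc(F)c2F)sc(N)c1C(=O)c1ccc(Cl)cc1`, gives 1%

Compound 3 stands level with compounds 1 and 2 in this assay; its nearest neighbour is compound 1 and its furthest is compound 2, and against both the gap lies within the scatter. Within the data shown here, the only single-point step measured so far is no change at the digits printed from compound 1 to compound 2 (within the scatter), phenyl in place of methyl on an aromatic carbon. Compound 4, `COc1cccc(-c2sc(N)c(C(=O)c3ccc(Cl)cc3)c2CC(C)(C)C)c1`, differs from compound 3 at one place: 3-methoxyphenyl in place of 2,3-difluorophenyl on an aromatic carbon. Among the measured compounds shown here, no measured step touches the aryl group next to the ring sulfur, so the one step on hand bears on it only loosely, and it showed nothing beyond the scatter. Compound 4 is therefore expected to stay at the same level, with a step of a number 1 percentage points higher from compound 3 to compound 4 (within the scatter) that is estimated to lie within the scatter. The estimate for compound 4 in this assay is 2%, in the range 0% to 14%.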

Compound 4, a percentage reported as inhibition, at one concentration (the size of the read-out at that concentration, not a potency): 1%
Compound 4: the middle estimate sits 1 percentage points above what was measured, and the stated range covers the measured number.
By their numbers in this assay, from the lowest: compounds 1, 2, 3 and 4 (each within the scatter of the next).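

In this assay, the change on the aromatic carbon next to the ring sulfur, 3-methoxyphenyl in place of 2,3-difluorophenyl, gives no change at the digits printed from compound 3 to compound 4 (within the scatter). Among these compounds, this is the first reading at this position, and the entering group brings a hydrogen-bond acceptor that the leaving group lacks, with no shift in the read-out. No evidence on hand explains this flat result.

On these data alone, whether an amine or a carboxylic acid on this aryl ring would lift the reading stays open. So does whether replacing the neopentyl group with a longer chain would.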